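The source may hold more compounds than are shown below. What is called first, only, known or untested is meant among the compounds shown, and "the series" means these compounds.

Measured so far in a functional assay on HL-60 cells (Homo sapiens), read by colorimetric assay, with a stated time of 24 h; on this read-out lower numbers stand for stronger inhibition and higher numbers for weaker inhibition:
Compound 1 `OC[C@@H](O)[C@H]1O[C@@H](n2cnc3c(Cl)nc(Cl)nc32)[C@H](O)[C@@H]1O`: > 100000 nM, a limit.
Compound 2 `Nc1nc(Cl)nc2c1ncn2[C@@H]1O[C@H]([C@H](O)CO)[C@@H](O)[C@H]1O`: > 100000 nM, a limit.
Compound 3 `CNc1ncnc2c1ncn2[C@@H]1O[C@H]([C@H](O)CO)[C@@H](O)[C@H]1O`: > 100000 nM, a limit.

Compound 3 has no number of its own, only a limit, and the other two compounds fare no differently: this is the limit of > 100000 nM in this assay, at which 3 of the 3 values shown sit. Compound 4 `CNc1nc(Cl)nc2c1ncn2[C@@H]1O[C@H]([C@H](O)CO)[C@@H](O)[C@H]1O` differs from compound 3 by one change, chloro in place of hydrogen on an aromatic carbon, between two ring nitrogen atoms.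

Among the compounds with values here, only one measured step bears on this change. It is a step that the two limits leave unreadable from compound 1 to compound 2, which also concerns a chloro on an aromatic carbon but gives no size to carry over. Compound 2 already carries this chloro, and its result in this assay is still the limit of > 100000 nM. On that ground, no step beyond the scatter can be expected in either direction, and compound 4 is expected to reach the same limit. The estimate for compound 4 is 100000 nM, with an expected range from 30000 nM to 300000 nM. This estimate amounts to a number no higher from compound 3 to compound 4 (the limit leaves the size open).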

Compound 4, half-maximal inhibitory concentration: > 100000 nM
Compound 4: a limit, no number; the forecaster's own chance of this, stated with the estimate: 85%; the middle value sits exactly at the limit.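

Compound 4 also stays at a limit, so no step from compound 1, compound 2 or compound 3 to compound 4 can be read in this assay: the limit of > 100000 nM in this assay, at which 4 of the 4 values shown sit.

The compounds shown leave open whether chloro, amino or methylamino on the shared core makes any difference to inhibition at all.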